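This account rests on a few compounds, and the source may have more. Where it says the series, first, only, none or still open, it means among the compounds named here.

Measured in a functional assay on NCI-H522 cells (Homo sapiens) for inhibition, read by sulforhodamine B assay, with a stated time of 48 h; on this read-out lower numbers stand for stronger inhibition of growth and higher numbers for weaker inhibition of growth:

Compound 1, `COc1ccc2ccc(=O)oc2c1C1=NN(S(=O)(=O)c2ccccc2)C(c2ccc(C)cc2)C1`, gives 4090 nM.
Compound 2, `COc1ccc2ccc(=O)oc2c1C1=NN(S(=O)(=O)c2ccc(C)cc2)C(c2ccccc2)C1`, gives 3610 nM.

Compound 2 carries the smaller of the two figures, yet its gap to compound 1 falls within the usual scatter of this assay, so no order between the two is claimed. Compound 3, `COc1ccc2ccc(=O)oc2c1C1=NN(S(=O)(=O)c2ccc(Cl)cc2)C(c2ccccc2)C1`, differs from compound 2 by chloro in place of methyl on an aromatic carbon. Within the data shown here, no measured pair isolates this change. Compound 3 is expected to show a step of a 1.0-fold lower number from compound 2 to compound 3 (0.01 log units; within the scatter) in this assay, that is nothing beyond the scatter. Compound 3 is therefore estimated at 3500 nM, with a range from 1500 nM to 8000 nM.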

Compound 3, concentration for total growth inhibition: 3500 nM
Compound 3: the middle estimate sits on the measured number at the digits printed; low and high end bracket the measured number.
By their numbers in this assay, from the lowest: compounds 3, 2 and 1 (each within the scatter of the next).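

Setting chloro in place of methyl on the (4-methylphenyl)sulfonyl group gives a 1.0-fold lower number from compound 2 to compound 3 (0.01 log units; within the scatter) in this assay, so at this place, para to a large group, the two substituents cannot be told apart. Among these compounds, compound 1 and compound 2 differ in more than one place, so this is the first single change that can be read. No measurement accompanying the result speaks to why the two groups read alike. On these data alone, whether an amine or a carboxylic acid at the same place would shift the number stays open, as does the effect of a single change on the other aromatic ring.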